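The source may report more compounds than this note shows. Statements on the series, on what has been measured and on what is new or still open speak of the compounds shown alone.

Measured compounds in an ADME assay on MT4 cells (Homo sapiens) for cytotoxicity, read by MTT assay; a higher number here means that more compound is tolerated, a lower number that less compound is tolerated:
Compound 1 `Cc1ccc(N(C(=O)c2ccc([N+](=O)[O-])cc2)C(=S)OCCN2C(=O)c3ccccc3C2=O)cc1`: 58000 nM
Compound 2 `O=C1c2ccccc2C(=O)N1CCOC(=S)N(C(=O)c1c(Cl)cccc1Cl)c1ccc(Cl)cc1`: 20000 nM
Compound 3 `Cc1ccc(N(C(=O)c2ccc(F)cc2F)C(=S)OCCN2C(=O)c3ccccc3C2=O)cc1`: 20000 nM

Compound 3, at 20000 nM, stands level with compound 2, and together they hold the lowest number of the three, while compound 1 lies higher. The next compound, compound 4 `Cc1ccc(N(C(=O)c2c(Cl)cccc2Cl)C(=S)OCCN2C(=O)c3ccccc3C2=O)cc1`, has 2,6-dichlorophenyl in place of 2,4-difluorophenyl on a carbonyl carbon. Among the compounds with values here, only one measured step changes the group at this place: a 2.9-fold lower number from compound 1 to compound 3 (0.46 log units; beyond the scatter). That modest step lies beyond the scatter, but it involved a different departing group. Compound 2 already carries the entering 2,6-dichlorophenyl group and gives 20000 nM, although it differs from compound 4 elsewhere in the structure. These data therefore suggest no clear direction, and no step beyond the scatter is expected in this assay. The estimated change is small: a 1.1-fold higher number from compound 3 to compound 4 (0.04 log units; within the scatter). For compound 4 the expected value is 22000 nM, with an estimated range from 10000 nM to 50000 nM.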

Compound 4, half-maximal cytotoxic concentration: 22000 nM
Compound 4: the middle estimate sits on the measured number at the digits printed; measured number inside the range.
By their numbers in this assay, from the lowest: compounds 2, 3 and 4 (each within the scatter of the next); then compound 1.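

In this assay, 2,6-dichlorophenyl in place of 2,4-difluorophenyl on a carbonyl carbon gives a 1.1-fold higher number from compound 3 to compound 4 (0.04 log units; within the scatter), so these two groups are not separated at this place. Methyl in place of chloro on an aromatic carbon, read here for the first time with 2,6-dichlorophenyl held constant, gives a 1.1-fold higher number from compound 2 to compound 4 (0.04 log units; within the scatter), and this change also shows no separation. Replacing 4-nitrophenyl with 2,6-dichlorophenyl gives a 2.6-fold lower number from compound 1 to compound 4 (0.42 log units; beyond the scatter), which matches the direction of a 2.9-fold lower number from compound 1 to compound 3 (0.46 log units; beyond the scatter) and leaves compound 1 alone at the higher number.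

The compounds shown leave open whether an unsubstituted phenyl or a 4-methoxyphenyl group on this carbonyl carbon would stay with compound 3 and compound 4 or move toward compound 1. No measurement available here bears on why these numbers fall as they do.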